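Methoxy in Place of Hydrogen, Repeated on a Second Core

The source may report more compounds than this note shows. Statements on the series, on what has been measured and on what is new or still open speak of the compounds shown alone.

Measured in a functional assay on MCF7 cells (Homo sapiens), tested at 7.5 uM; a lower number here means a stronger effect, a higher number a weaker effect of the compound at the concentration tested:
compound 1 `C=CCOc1c(C)c(C)c2c(c1C)CCC(C)(COc1ccc(/C=C3\SC(=O)NC3=O)cc1)O2`: 2%
compound 2 `C=CCOc1c(C)c(C)c2c(c1C)CCC(C)(COc1ccc(/C=C3\SC(=O)NC3=O)cc1OC)O2`: 1%
compound 3 `CC(C)=CCOc1c(C)c(C)c2c(c1C)CCC(C)(COc1ccc(/C=C3\SC(=O)NC3=O)cc1)O2`: 5%

Compound 2 differs from compound 1 by methoxy in place of hydrogen on an aromatic carbon, and this change gave a number 1 percentage points lower from compound 1 to compound 2 (within the scatter). Compound 3 differs from compound 1 in its core by 2-methylprop-1-en-1-yl in place of vinyl on a saturated chain carbon bound to an oxygen on an aromatic ring, a change that gave a number 3 percentage points higher from compound 1 to compound 3 (within the scatter); all three values lie within the scatter of one another.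

Compound 4 `COc1cc(/C=C2\SC(=O)NC2=O)ccc1OCC1(C)CCc2c(C)c(OCC=C(C)C)c(C)c(C)c2O1` is not yet measured. It differs from compound 3 by methoxy in place of hydrogen on an aromatic carbon, the same change already seen from compound 1 to compound 2, at a place described in identical words. Compound 4 is therefore expected to show a number 1 percentage points lower from compound 3 to compound 4 (within the scatter), a step within the scatter like the earlier one, because of a number 1 percentage points lower from compound 1 to compound 2 (within the scatter). For compound 4 the expected value in this assay is 4%, estimated between 0% and 12%.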

Compound 4, a percentage reported as activity, at one concentration (the size of the read-out at that concentration, not a potency): 54%
Compound 4: the middle estimate sits 50 percentage points below what was measured; measured number above the stated range.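

In this assay, methoxy in place of hydrogen on an aromatic carbon gave a number 49 percentage points higher from compound 3 to compound 4 (beyond the scatter), so this change did not carry over from the core of compound 1 to the core of compound 3: the same change on two cores in this assay, a number 1 percentage points lower (within the scatter) from compound 1 to compound 2 and a number 49 percentage points higher (beyond the scatter) from compound 3 to compound 4, 50 percentage points apart, beyond the scatter of two such steps. Likewise, 2-methylprop-1-en-1-yl in place of vinyl gave a number 53 percentage points higher from compound 2 to compound 4 (beyond the scatter), so its outcome also depended on the core: the same change on two cores in this assay, a number 3 percentage points higher (within the scatter) from compound 1 to compound 3 and a number 53 percentage points higher (beyond the scatter) from compound 2 to compound 4, 50 percentage points apart, beyond the scatter of two such steps. This shows that the two changes do not simply add up in these four compounds, but it rests on a single compound and does not show why.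

The compounds shown leave open whether ethoxy or hydroxyl in place of methoxy would give a similar step on the core of compound 3. They also leave open whether a longer chain in place of 2-methylprop-1-en-1-yl would do so.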